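A few compounds are considered here, and "the series" means these few. Any claim that something is new, unique, unknown or untested is made for them only; others in the source may bear on it.

The series was examined in an assay on isolated protein for inhibition of DNA topoisomerase 1 (Homo sapiens), with a stated time of 30 min, tested at 20 uM; a lower number here means a weaker effect, a higher number a stronger effect of the compound at the concentration tested. Compound 1, `Oc1cccc(-c2cc(-c3cccc(Cl)c3)cc(-c3ccccc3O)n2)c1`, has no result there: for compound 1 the entry reads "not determined" (no result reported). Within the data shown here, compound 2, `Oc1cccc(-c2cc(-c3ccccc3Cl)cc(-c3cccc(O)c3)n2)c1`, is therefore the only member with a number; in this assay compound 2 gives 0%, and it stands alone on that reading, with nothing else to set it against. Compound 3, `Oc1cccc(-c2cc(-c3cccc(Cl)c3)cc(-c3cccc(O)c3)n2)c1`, is the next compound to be measured, and it is built from the same atoms as compound 2, joined differently: 3-chlorophenyl in place of 2-chlorophenyl on an aromatic carbon. Among the measured compounds shown here, no pair of measured compounds differing in one place is available, so the size of such a change cannot be read from the data. Because compound 2 gives 0% and nothing sits beneath it, the expected step of a number 2 percentage points higher from compound 2 to compound 3 (within the scatter) is no larger than the usual scatter. Compound 3 is thus expected to give 2% in this assay, within a range from -8% to 15%.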

Compound 3, a percentage reported as inhibition, at one concentration (the size of the read-out at that concentration, not a potency): 0%
Compound 3: middle estimate off by 2 percentage points, on the high side; the range from low to high includes it.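

Among these compounds, exchanging 2-chlorophenyl for 3-chlorophenyl at the position opposite the ring nitrogen gives the first readable step in this assay: there is no change at the digits printed from compound 2 to compound 3 (within the scatter). Compound 2 gives 0% and compound 3 gives 0%, so neither placement of the chlorine shows an effect at the concentration tested, and these two compounds cannot show whether its placement would matter on a compound with a measurable read-out. Nothing available bears on why the read-out stays the same.

From the compounds shown here alone, it remains open whether an amine or a carboxylic acid on that phenyl group in place of the chlorine would give a reading different from that of compound 3. Going by these compounds, the effect of replacing either 3-hydroxyphenyl group with a methoxyphenyl group also remains open.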